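The compounds below may be only part of what the source reports. "The series", "measured", "known", "first", "only" and "open" are said of these compounds alone.

Measured in a functional assay on P388 cells (Mus musculus) for antiproliferative activity; on this read-out lower numbers stand for stronger inhibition and higher numbers for weaker inhibition:
Compound 1 `COC1=C(OCc2ccc([N+](=O)[O-])cc2)/C(=C\Cn2cnc3c(Cl)ncnc32)OC1=O`: 6490 nM
Compound 2 `COC1=C(OCc2ccc([N+](=O)[O-])cc2)C(=O)O/C1=C/Cn1cnc2c(Cl)ncnc21`: 7420 nM

Compound 2 stands at 7420 nM, within the scatter of compound 1, so the two numbers cannot be told apart in this assay. Compound 3 `O=C1O/C(=C/Cn2cnc3c(Cl)ncnc32)C(OCc2ccc([N+](=O)[O-])cc2)=C1OCc1ccc([N+](=O)[O-])cc1` follows from compound 2 with 4-nitrophenyl in place of hydrogen on a saturated chain carbon bound to an oxygen on an unsaturated carbon. Among the compounds with values here, no measured step shows what such a change does, so only a modest shift toward stronger inhibition is expected. The expected size is a 1.5-fold lower number from compound 2 to compound 3 (0.17 log units; within the scatter). For compound 3 the estimated value is 5000 nM, with an expected range of 1500 nM to 15000 nM.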

Compound 3, half-maximal inhibitory concentration: > 120000 nM
Compound 3: only a limit was reported; the forecaster's own chance of this, stated with the estimate: 3%; middle value at least 24-fold (1.38 log units) from the limit.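

In this assay, the change from methoxy to (4-nitrobenzyl)oxy on this position gives an at least 16-fold higher number from compound 2 to compound 3 (1.20 log units; beyond the scatter), and the same comparison gives an at least 18-fold higher number from compound 1 to compound 3 (1.26 log units; beyond the scatter). The earlier compounds shown here showed no step at this position; these steps show that activity depends strongly on the group held there. For compound 3 the reading is a limit and not a number: the limit of > 120000 nM in this assay, at which 1 of the 3 values shown sits.

The compounds shown leave open whether the drop goes with the nitro group or with the aromatic ring itself. A plain benzyl group, or an amine in place of the nitro group, would separate the two.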